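The source may report more compounds than this note shows. Statements on the series, on what has been measured and on what is new or still open speak of the compounds shown alone.

Compound 1, with the structure `COc1cc(OC)cc(C(=O)NC2CCN(Cc3ccc4ccccc4c3)CC2)c1`, is the best-placed of the three measured compounds. In an assay on isolated protein for binding affinity to melanin-concentrating hormone receptor 1 (Homo sapiens) (on this read-out lower numbers stand for stronger inhibition and higher numbers for weaker inhibition), compound 1 gives 27 nM, the lowest number of the set. Compound 2, `CCOc1cc(OCC)cc(C(=O)NC2CCN(Cc3ccc4ccccc4c3)CC2)c1`, carries ethoxy groups where methoxy groups stand in the first compound; compound 2 gives 56 nM. Going by the values given here, compound 3, `COc1cc(C(=O)NC2CCN(Cc3ccc4ccccc4c3)CC2)cc(OC)c1OC`, which carries a further methoxy group on the same ring, gives 286 nM, and the single step of an 11-fold higher number from compound 1 to compound 3 (1.03 log units; beyond the scatter) is the only one-change comparison on record for this part of the molecule.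

Compound 4, `O=C(NC1CCN(Cc2ccc3ccccc3c2)CC1)c1cc(F)cc(F)c1`, has not yet been measured. It differs from compound 1 by 3,5-difluorophenyl in place of 3,5-dimethoxyphenyl on a carbonyl carbon. Among the compounds with values here, no measured step covers this exact replacement. What the two comparisons show is that changing the substituents of this ring, whether by lengthening them in compound 2 or by adding one in compound 3, has so far only raised the number, and in compound 3 by a large margin. As far as these compounds go, on that basis compound 4 is expected to give a somewhat higher number than compound 1, by a step estimated at a 2.6-fold higher number from compound 1 to compound 4 (0.41 log units; beyond the scatter), though the direction is uncertain since the change is untested. The estimate for compound 4 is 70 nM, within a range of 20 nM to 250 nM.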

Compound 4, inhibition constant: 65 nM
The estimate for compound 4 lay 1.1-fold (0.03 log units) above the measured number; low and high end bracket the measured number.
By their numbers in this assay, from the lowest: compound 1; then compounds 2 and 4 (each within the scatter of the next); then compound 3.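

Replacing 3,5-dimethoxyphenyl with 3,5-difluorophenyl on the carbonyl carbon gives a 2.4-fold higher number from compound 1 to compound 4 (0.38 log units; beyond the scatter) in this assay, so this position has now been tested with a ring that carries no oxygen at all. The entering group has none of the hydrogen-bond acceptors counted for the group it replaces, and it has fewer heavy atoms, yet the step is modest, whereas the step to compound 3 is large; the methoxy groups of compound 1 are therefore not required for binding in the nanomolar range, although compound 1 keeps the lowest number and each change to this ring among compounds 2, 3 and 4 has raised it, with no compound shown going against that. Nothing at hand accounts for the size or direction of this step. The compounds shown leave open whether any other group on this ring could bring the number below that of compound 1, for instance chlorine, a nitrile, a hydroxyl or an amine in place of the fluorines. They also leave open whether a ring with a single fluorine or a single methoxy group would stand closer to compound 1 or further from it.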